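A few compounds are considered here, and "the series" means these few. Any claim that something is new, unique, unknown or untested is made for them only; others in the source may bear on it.

Measured compounds: compound 1 `COc1ccccc1-c1nnc(Nc2ccc(C)cc2)s1`, 58100 nM; compound 2 `COc1cccc(Nc2nnc(-c3ccc(Br)cc3)s2)c1`, 31100 nM; compound 3 `COc1ccc(-c2nnc(Nc3ccc(C)cc3)s2)c(OC)c1`, 39300 nM.

All three were tested in an assay on isolated protein for inhibition of beta-glucuronidase (Bos taurus), read by spectrophotometry, with a stated time of 30 min; a lower number here means a stronger inhibitor, a higher number a weaker inhibitor. Compound 3 and compound 1 differ in one place, (hydrogen in place of methoxy on an aromatic carbon), and the step of a 1.5-fold higher number from compound 3 to compound 1 (0.17 log units; within the scatter). Compound 4 `Brc1ccc(-c2nnc(Nc3ccccc3)s2)cc1` has not yet been measured; it differs from compound 2 by hydrogen in place of methoxy on an aromatic carbon. This is the same kind of change, though here the place is meta to a large group, whereas in compound 3 it is meta to a methoxy group and para to a large group. The difference between the core of compound 2 and that of compound 3 is not broken down here. The step from compound 3 to compound 1 lay within the scatter. On that basis a step of like size is expected, a 1.4-fold higher number from compound 2 to compound 4 (0.13 log units; within the scatter). Compound 4 is therefore estimated at 42000 nM, with a range from 15000 nM to 110000 nM.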

Compound 4, half-maximal inhibitory concentration: 40200 nM
Compound 4: the middle estimate sits 1.0-fold (0.02 log units) above what was measured; the measured number falls inside the stated range.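

In this assay putting hydrogen in place of methoxy on an aromatic carbon gives a 1.3-fold higher number from compound 2 to compound 4 (0.11 log units; within the scatter) and so agrees with the earlier step on the other core: the same change on two cores in this assay, a 1.5-fold higher number (0.17 log units; within the scatter) from compound 3 to compound 1 and a 1.3-fold higher number (0.11 log units; within the scatter) from compound 2 to compound 4, 1.1-fold (0.06 log units) apart, within the scatter of two such steps. Within the data shown here, on these two cores, then, the change carried across with no step that stands clear of the scatter, and the two steps cannot be told apart. This does not show that methoxy matters for the number at either place, and two cores are too few to set a rule for the series.

The compounds shown leave open what other groups at this place, such as an amine, a carboxylic acid or a longer chain, would give. They also leave open whether the same change would behave alike on other cores.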